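The source may report more compounds than this note shows. Statements on the series, on what has been measured and on what is new or still open speak of the compounds shown alone.

Notes on the series in an ADME assay on the whole organism for pharmacokinetics, with Rattus norvegicus as the target, at a dose of 3 mg/kg by the intravenous route; a lower number here means slower removal, a higher number faster removal of the compound.

Of the compounds shown here, three have been measured. Compound 1 `COC(=O)N[C@H](C(=O)N1CCC[C@H]1C(=O)Nc1ccc([C@@H]2CC[C@@H](c3ccc(NC(=O)[C@@H]4CCCN4C(=O)[C@@H](NC(=O)OC)[C@@H](C)OC)cc3)N2c2ccc(F)cc2)cc1)[C@@H](C)OC` gives 56.7 mL/min/kg. Compound 2 `COC(=O)N[C@H](C(=O)N1CCC[C@H]1C(=O)Nc1ccc([C@@H]2CC[C@@H](c3ccc(NC(=O)[C@@H]4CCCN4C(=O)[C@@H](NC(=O)OC)C(C)C)cc3)N2c2ccc(F)cc2)cc1)C(C)C` gives 15 mL/min/kg. Compound 3 `COC(=O)N[C@H](C(=O)N1CCC[C@H]1C(=O)Nc1ccc([C@H]2CC[C@H](c3ccc(NC(=O)[C@@H]4CCCN4C(=O)[C@@H](NC(=O)OC)[C@H]4CCOC4)cc3)N2c2ccc(F)cc2)cc1)[C@H]1CCOC1` gives 66.7 mL/min/kg. Compound 1 stands second highest of the three: the number for compound 3 is within the scatter of it, while compound 2 sits clearly lower, beyond the scatter.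

Compound 4 `COC(=O)N[C@H](C(=O)N1CCC[C@H]1C(=O)Nc1ccc([C@H]2CC[C@H](c3ccc(NC(=O)[C@@H]4CCCN4C(=O)[C@@H](NC(=O)OC)[C@@H](C)OC)cc3)N2c2ccc(F)cc2)cc1)[C@@H](C)OC` is still unmeasured. Relative to compound 1 the change is as follows: the two compounds have the same atoms and bonds and differ only in configuration as drawn: 2 of 8 stereo elements differ; a stereocentre at a saturated ring carbon is drawn S in compound 1 and R in compound 4; a stereocentre at a saturated ring carbon is drawn S in compound 1 and R in compound 4. Compound 3 carries the same drawn configuration at those ring carbons as compound 4, and compound 2 the same as compound 1, yet compound 3 and compound 1 lie within the scatter of each other while compound 2 is far lower, so the core configuration by itself shows no consistent effect on this assay in these three compounds.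

For the step from compound 1 to compound 4, no movement beyond the scatter is expected, in either direction, a 1.0-fold lower number from compound 1 to compound 4 (0.01 log units; within the scatter). Compound 4 is therefore estimated at 55 mL/min/kg, with a range from 27 mL/min/kg to 110 mL/min/kg.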

Compound 4, clearance in the Rattus norvegicus assay: 45 mL/min/kg
Compound 4: the middle estimate sits 1.2-fold (0.09 log units) above what was measured, within the range that was stated.
By their numbers in the Rattus norvegicus assay, from the lowest: compound 2; then compounds 4, 1 and 3 (each within the scatter of the next).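

Going by these compounds alone, in the Rattus norvegicus assay, changing the two saturated ring carbons of the shared core from S to R while everything else stays the same gives a 1.3-fold lower number from compound 1 to compound 4 (0.10 log units; within the scatter), so this pair provides the first direct reading of core configuration, and here it moves nothing beyond the scatter. In a physicochemical assay for solubility, in phosphate buffer, measured as kinetic solubility, at pH 7.2 (a higher number here means a more soluble compound, a lower number a less soluble compound), compound 1 gives 9600 nM and compound 4 gives 7700 nM, which is a 1.2-fold lower number from compound 1 to compound 4 (0.10 log units; within the scatter), so the same holds for this read-out. Both readings can be assigned to the drawn configuration alone: the fact that compounds 1 and 4 differ only in the configuration as drawn.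

As far as these compounds go, compound 2 and compound 3 have no partner of opposite core configuration here, so whether the result carries over to other side chains remains open. Within the data shown here, also open are the effect of inverting only one of the two ring carbons and how a side chain bearing an amine or a carboxylic acid would behave.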